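This account rests on a few compounds, and the source may have more. Where it says the series, first, only, none or still open, it means among the compounds named here.

The measured compounds:

Compound 1 `Cc1oc(=O)oc1COC(=O)c1cccc(NC(=O)[C@@H]2C[C@H](SC3=C(C(=O)O)N4C(=O)[C@H]([C@@H](C)O)[C@H]4[C@H]3C)CN2)c1`. In a physicochemical assay for metabolic stability, read by LC-MS, in phosphate buffer, with a stated time of 3 h, at pH 7.4, tested at 50 uM (a lower number here means that less of the compound is left, a higher number that more of the compound is left), compound 1 gives > 95%, which is a limit of the assay and not a number.
Compound 2 `CCOC(=O)C1=C(S[C@@H]2CN[C@H](C(=O)Nc3cccc(C(=O)O)c3)C2)[C@H](C)[C@@H]2[C@@H]([C@@H](C)O)C(=O)N12`. In this assay compound 2 gives > 95%, also a limit.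
Compound 3 `CC(C)OC(=O)c1cccc(NC(=O)[C@@H]2C[C@H](SC3=C(C(=O)O)N4C(=O)[C@H]([C@@H](C)O)[C@H]4[C@H]3C)CN2)c1`. In this assay compound 3 gives > 95%, again a limit.

Compound 3 thus stands where every value shown sits: the limit of > 95% in this assay, at which 3 of the 3 values shown sit. Compound 4 `CC(C)OC(=O)C1=C(S[C@@H]2CN[C@H](C(=O)Nc3cccc(C(=O)OC(C)C)c3)C2)[C@H](C)[C@@H]2[C@@H]([C@@H](C)O)C(=O)N12` differs from compound 3 by isopropyl in place of hydrogen on an oxygen next to a carbonyl group. Among the measured compounds shown here, the only measured step at an oxygen next to a carbonyl group is a step that the two limits leave unreadable from compound 1 to compound 3, and because of the limit of > 95% in this assay, at which 3 of the 3 values shown sit, its size cannot be read. No step beyond the scatter is therefore expected, so compound 4 is estimated at 97%, within 90% to 100%. The expected step is a step that the limit leaves unreadable from compound 3 to compound 4, and the result will most likely again be reported as a limit.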

Compound 4, percent of the compound remaining: > 95%
Compound 4 ended at the assay's limit; the forecaster's own chance of this, stated with the estimate: 85%; the middle value does not contradict the limit.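

Among the compounds shown here, no step between compound 3 and compound 4 can be read, as both values are limits: the limit of > 95% in this assay, at which 4 of the 4 values shown sit.
The compounds shown leave open whether in this assay any group on an oxygen next to a carbonyl group changes how much compound is left.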